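The source may hold more compounds than are shown below. What is called first, only, known or untested is meant among the compounds shown, and "the series" means these compounds.

Measured so far: compound 1 `Cc1ccc2c(c1)CC(C(=O)Nc1ccc(-c3cn[nH]c3)cc1)CO2`, 4000 nM; compound 2 `COc1cc(-c2cn[nH]c2)ccc1NC(=O)C1COc2ccc(F)cc2C1`, < 6 nM.

In an assay on cells for inhibition of Rho-associated protein kinase 2 (Homo sapiens) (on this read-out lower numbers stand for stronger inhibition and higher numbers for weaker inhibition), compound 1 gives 4000 nM. Compound 2 returns only a limit of the assay, < 6 nM, so its true value is not pinned down (the limit of < 6 nM in this assay, at which 1 of the 2 values shown sits). Compound 3 `COc1cc(-c2cn[nH]c2)ccc1NC(=O)C1COc2ccc(C)cc2C1` differs from compound 2 by methyl in place of fluoro on an aromatic carbon. Among the measured compounds shown here, no measured step isolates this exchange; compound 1 carries the methyl yet also lacks the methoxy of compound 2, so its value cannot be read as this step alone. The change is expected to stay close to the scatter, an at least 1.6-fold higher number from compound 2 to compound 3 (0.22 log units; that floor lies within the scatter). Compound 3 is estimated at 10 nM, between 3 nM and 60 nM.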

Compound 3, half-maximal inhibitory concentration: 35 nM
Estimate against measurement, compound 3: 3.5-fold (0.54 log units) below, and the stated range covers the measured number.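

Methyl in place of fluoro on an aromatic carbon gives an at least 5.8-fold higher number from compound 2 to compound 3 (0.76 log units; beyond the scatter) in this assay, so this position is not indifferent to the group it carries. The size of that step stays open at one end, since compound 2 stands at a limit: the limit of < 6 nM in this assay, at which 1 of the 3 values shown sits.
Among the compounds shown here, with the methyl held constant, methoxy in place of hydrogen on an aromatic carbon gives a 110-fold lower number from compound 1 to compound 3 (2.06 log units; beyond the scatter), a step that no earlier pair isolated.

The compounds shown leave open how chloro or nitrile would read at the fluoro and methyl position. From the compounds shown here alone, whether ethoxy or an amine could stand in place of the methoxy also remains open.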